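Acylurea thiazole hydrazones: removing one fluoro from the benzoyl

This account rests on a few compounds, and the source may have more. Where it says the series, first, only, none or still open, it means among the compounds named here.

Measured so far in a functional assay on A549 cells (Homo sapiens) for inhibition, read by MTT assay, with a stated time of 72 h; a higher number here means a weaker inhibitor, a lower number a stronger inhibitor:
- compound 1 `CN(C(=O)NC(=O)c1c(F)cccc1F)c1nc(C(F)(F)F)c(C(=O)N/N=C/c2cc(C(F)(F)F)cc(C(F)(F)F)c2)s1`: 17.3 ug/mL
- compound 2 `CN(C(=O)NC(=O)c1c(F)cccc1F)c1nc(C(F)(F)F)c(C(=O)N/N=C/c2cccc(C(F)(F)F)c2)s1`: 27.6 ug/mL
- compound 3 `Cc1nc(N(C)C(=O)NC(=O)c2c(F)cccc2F)sc1C(=O)N/N=C/c1cc(C(F)(F)F)cc(C(F)(F)F)c1`: 13 ug/mL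

All three numbers sit close together. Compound 1 stands second highest of the three; its nearest neighbour is compound 3 and its furthest is compound 2, and both steps are within the scatter: a 1.6-fold higher number from compound 1 to compound 2 (0.20 log units; within the scatter) and a 1.3-fold lower number from compound 1 to compound 3 (0.12 log units; within the scatter). Neither move at the hydrazone end of the molecule, nor the swap on the shared core, shifts the readout beyond what repeat measurements would show.

Compound 4 `CN(C(=O)NC(=O)c1ccccc1F)c1nc(C(F)(F)F)c(C(=O)N/N=C/c2cc(C(F)(F)F)cc(C(F)(F)F)c2)s1` is not yet measured. It differs from compound 1 as follows: hydrogen in place of fluoro on an aromatic carbon. Among the compounds with values here, this is a change on the (2,6-difluorophenyl)carbonyl part, a region untouched by the two measured steps, so no measured step bears on it directly. Within the data shown here, the only guidance is that the series so far has been flat in this assay, with each single change staying within the scatter.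

On that basis compound 4 is expected to land near compound 1, with a step of a 1.2-fold higher number from compound 1 to compound 4 (0.06 log units; within the scatter) in this assay, that is no change beyond the scatter. The estimate for compound 4 is 20 ug/mL, with a range from 9 ug/mL to 45 ug/mL.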

Compound 4, half-maximal inhibitory concentration: 5.43 ug/mL
Compound 4: the middle estimate sits 3.7-fold (0.57 log units) above what was measured; the measured number lies below the stated range.
By their numbers in this assay, from the lowest: compound 4; then compounds 3, 1 and 2 (each within the scatter of the next, the first and the last beyond it).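

Within the data shown here, the (2,6-difluorophenyl)carbonyl part is the first place where a single change moves the readout beyond the scatter: in this assay, going from 2,6-difluorophenyl to 2-fluorophenyl gives a 3.2-fold lower number from compound 1 to compound 4 (0.50 log units; beyond the scatter). The flat picture from the two earlier steps therefore does not extend to this part of the molecule, and the loss of one fluoro, a single heavy atom, is enough to give a modest shift towards stronger inhibition. Nothing in the available data accounts for this shift.

The compounds shown leave open whether the remaining fluoro on the 2-fluorophenyl ring can also be replaced by hydrogen, and whether a chloro, methyl or methoxy group in place of the departing fluoro would give a similar number. They also leave open whether the same change from fluoro to hydrogen gives a similar step when carried out on compound 2 or compound 3, where the other two measured changes are present.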